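Swapping the phenyl on an oxazole core for a bromo-methoxy ring

The source may report more compounds than this note shows. Statements on the series, on what has been measured and on what is new or still open speak of the compounds shown alone.

Measured compounds:
Compound 1, `COc1ccc(Br)cc1-c1nc(CNC[C@@H]2CCN(Cc3ccccc3)C2)c[nH]1`, gives 1110 nM in an assay on CHO cells for displacement of a labelled ligand from D(4) dopamine receptor (Homo sapiens); a higher number here means a weaker inhibitor, a lower number a stronger inhibitor.
Compound 2, `c1ccc(CN2CCC(NCc3coc(-c4ccccc4)n3)CC2)cc1`, gives 350 nM in this assay.
Compound 3, `COc1ccc(Br)cc1-c1nc(CN2CCN(c3ccccc3)CC2)co1`, gives 370 nM in this assay.

Compound 2 has the lowest number of the three, but compound 3 sits within the scatter of it, so the two cannot be told apart; only compound 1 stands clearly apart, with a higher number beyond the scatter. Compound 4, `COc1ccc(Br)cc1-c1nc(CNC2CCN(Cc3ccccc3)CC2)co1`, arises from compound 2 by 5-bromo-2-methoxyphenyl in place of phenyl on an aromatic carbon. Among the compounds with values here, no measured pair isolates this change alone. Compound 3 carries the same entering group and matches compound 2, so little shift is expected: the step from compound 2 to compound 4 is estimated as a 1.2-fold higher number from compound 2 to compound 4 (0.08 log units; within the scatter), essentially none beyond the scatter. Compound 4 is thus expected to give about 420 nM, between 150 nM and 1200 nM.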

Compound 4, inhibition constant: 390 nM
Compound 4: the middle estimate sits 1.1-fold (0.03 log units) above what was measured; low and high end bracket the measured number.
By their numbers in this assay, from the lowest: compounds 2, 3 and 4 (each within the scatter of the next); then compound 1.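

In this assay, within the data shown here, 5-bromo-2-methoxyphenyl in place of phenyl gives a 1.1-fold higher number from compound 2 to compound 4 (0.05 log units; within the scatter), the first direct reading of this change with the rest of the molecule held constant. This aromatic carbon, next to the ring nitrogen and the ring oxygen, therefore takes the larger group and its added hydrogen-bond acceptor with no shift that can be told from scatter. No measurement at hand gives a reason for this. The bromo and methoxy groups appear only together, leaving the contribution of each alone open. Also open, as far as these compounds go, is whether a carboxylic acid or an amine on this ring would move the number beyond the scatter.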